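From a Hydroxyethyl Amine to a Cyanophenyl Amine

This account rests on a few compounds, and the source may have more. Where it says the series, first, only, none or still open, it means among the compounds named here.

The compounds are followed in an ADME assay on CHO cells (Cricetulus griseus) for cytotoxicity, read by MTT assay; a lower number here means a stronger inhibitor, a higher number a weaker inhibitor. Compound 1, `Cc1cc(-c2ccccc2)n(-c2nc(C(F)(F)F)cc(=O)[nH]2)n1`, gives > 50000 nM in this assay, and that value is a limit of the assay rather than a number. Compound 2, `Cc1cc(NCCO)n(-c2nc(C(F)(F)F)cc(=O)[nH]2)n1`, carries a 2-hydroxyethyl group on a nitrogen on an aromatic ring of the shared core; in this assay compound 2 has "not determined" (no result reported), so no single number stands for it. For the measured compounds named here, the one further value shown in this assay is the limit of > 50000 nM in this assay, at which 1 of the 2 values shown sits.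

Compound 3, `Cc1cc(Nc2ccc(C#N)cc2)n(-c2nc(C(F)(F)F)cc(=O)[nH]2)n1`, differs from compound 2 by 4-cyanophenyl in place of 2-hydroxyethyl on a nitrogen on an aromatic ring. No step between two measured compounds is shown, so the size of the change from compound 2 to compound 3 in this assay cannot be read from any measured pair. With only a limit for compound 1 and no number for compound 2, the expectation for compound 3 rests on little, and no shift beyond the usual scatter is expected in either direction. Compound 3 is expected to give 50000 nM in this assay, with a range from 20000 nM to 100000 nM, and it is likely that this assay again reports only a limit.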

Compound 3, half-maximal inhibitory concentration: 20000 nM
The estimate for compound 3 lay 2.5-fold (0.40 log units) above the measured number; the measured number falls inside the stated range.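

For the compounds shown here, compound 2 has no result in this assay, and no step from compound 2 to compound 3 can be read; compound 3 stands alone at 20000 nM. The compounds shown leave open how far 4-cyanophenyl in place of 2-hydroxyethyl on a nitrogen on an aromatic ring shifts the value in this assay.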